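The compounds below may be only part of what the source reports. "The series", "measured", "known", "first", "only" and "open" are said of these compounds alone.

Measured so far in an assay on isolated protein for binding affinity to secreted frizzled-related protein 1 (Homo sapiens), read by fluorescence; a lower number here means a stronger inhibitor, a higher number a weaker inhibitor:
compound 1 `O=C1CC[C@@H](C(=O)N2CCC(NS(=O)(=O)c3cc(S(=O)(=O)c4ccccc4)ccc3C(F)(F)F)CC2)N1` gives 90 nM
compound 2 `CC(C)(C)CCN1CCC[C@H]1C(=O)N1CCC(NS(=O)(=O)c2cc(S(=O)(=O)c3ccccc3)ccc2C(F)(F)F)CC1` gives 30 nM

Compound 2 holds the lowest of the two numbers; its nearest neighbour is compound 1, and going from 5-oxopyrrolidin-2-yl to 1-(3,3-dimethylbutyl)pyrrolidin-2-yl on the carbonyl carbon brought a 3.0-fold lower number from compound 1 to compound 2 (0.48 log units; beyond the scatter), a modest gain. Compound 3 `O=C([C@@H]1CCCN1Cc1ccccc1)N1CCC(NS(=O)(=O)c2cc(S(=O)(=O)c3ccccc3)ccc2C(F)(F)F)CC1` has not yet been measured. It differs from compound 2 by phenyl in place of neopentyl on a saturated chain carbon bound to an amine nitrogen in a ring. Within the data shown here, no measured step covers this exact exchange: the one known step, a 3.0-fold lower number from compound 1 to compound 2 (0.48 log units; beyond the scatter), concerns the whole substituent on the ring nitrogen rather than a swap of one terminal group for another on the same chain. The expected change in this assay is therefore small, in either direction, and most likely within the scatter. For compound 3 the estimate is 40 nM, with a range from 15 nM to 120 nM. This estimate corresponds to an expected step of a 1.3-fold higher number from compound 2 to compound 3 (0.12 log units; within the scatter).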

Compound 3, half-maximal inhibitory concentration in the secreted frizzled-related protein 1 assay: 1400 nM
For compound 3 the middle estimate is 35-fold (1.54 log units) below the measured one, outside the stated range (above it).
By their numbers in the secreted frizzled-related protein 1 assay, from the lowest: compound 2; then compound 1; then compound 3.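

In the secreted frizzled-related protein 1 assay this position proved far less forgiving than the earlier pair suggested: phenyl in place of neopentyl gave a 47-fold higher number from compound 2 to compound 3 (1.67 log units; beyond the scatter) even though neopentyl has 5 heavy atoms, phenyl has 6 heavy atoms, and neither carries a hydrogen-bond donor or acceptor. The 1-benzylpyrrolidin-2-yl group also fell behind the 5-oxopyrrolidin-2-yl group, with a 16-fold higher number from compound 1 to compound 3 (1.19 log units; beyond the scatter), so a substituent on the ring nitrogen does not by itself retain the number seen with 3,3-dimethylbutyl. In a physicochemical assay for solubility (a lower number here means a less soluble compound, a higher number a more soluble compound), compound 2 gives 12500 nM and compound 3 gives 25000 nM; the exchange of neopentyl for phenyl reads a 2.0-fold higher number from compound 2 to compound 3 (0.30 log units; within the scatter), so that read-out does not follow the large step in binding.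

Nothing available explains the loss. The compounds shown leave open whether it follows the aromatic ring or the shape of the chain, a question that cyclohexylmethyl or phenethyl on the same nitrogen would address.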